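Side-chain amine exchange in an acrylamide quinazoline series

This account rests on a few compounds, and the source may have more. Where it says the series, first, only, none or still open, it means among the compounds named here.

Three compounds in this series have numbers in a functional assay on PC-3 cells (Homo sapiens) for antiproliferative activity, read by MTT assay, with a stated time of 72 h; on this read-out lower numbers stand for stronger inhibition and higher numbers for weaker inhibition. Compound 1 `O=C(/C=C/CN1CCC(CO)CC1)Nc1cc2c(N3CCc4ccccc43)ncnc2cc1O[C@@H]1CCOC1` gives 3310 nM. Compound 2 `COc1cc2ncnc(N3CCCc4ccccc43)c2cc1NC(=O)/C=C/CN1CCC(CO)CC1` gives 7150 nM. Compound 3 `CN(C)C/C=C/C(=O)Nc1cc2c(N3CCCc4ccccc43)ncnc2cc1O[C@@H]1CCOC1` gives 4170 nM, which stands second highest of the three; its nearest neighbour is compound 1 and its furthest is compound 2, and both of those gaps lie within the scatter of this assay, so the three cannot be ordered against one another. None of the three pairs differs in only one place, so no single step can be read off.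

Compound 4 `O=C(/C=C/CN1CCC(CO)CC1)Nc1cc2c(N3CCCc4ccccc43)ncnc2cc1O[C@@H]1CCOC1` is not yet measured. It differs from compound 3 in one place: 4-(hydroxymethyl)piperidin-1-yl in place of dimethylamino on a saturated chain carbon bound to a double-bonded chain carbon. The entering group is the same one carried by compound 1 and compound 2, whose values in this assay sit in the same band as that of compound 3. On that basis no move beyond the scatter is expected; the step from compound 3 to compound 4 is estimated at a 1.2-fold lower number from compound 3 to compound 4 (0.06 log units; within the scatter), with no preferred direction. For compound 4 the expected value in this assay is 3600 nM, with a range from 1500 nM to 8500 nM.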

Compound 4, half-maximal inhibitory concentration: 5460 nM
The estimate for compound 4 lay 1.5-fold (0.18 log units) below the measured number, and the stated range covers the measured number.
By their numbers in this assay, from the lowest: compounds 1, 3, 4 and 2 (each within the scatter of the next, the first and the last beyond it).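

In this assay, the chain position now has a reading in one place: 4-(hydroxymethyl)piperidin-1-yl in place of dimethylamino on a saturated chain carbon bound to a double-bonded chain carbon gives a 1.3-fold higher number from compound 3 to compound 4 (0.12 log units; within the scatter), so this much larger entering group, with its ring and hydroxyl, leaves the number within the scatter. Compound 4 also links the two other compounds to this pair, and oxolan-3-yl in place of methyl on an oxygen on an aromatic ring gives a 1.3-fold lower number from compound 2 to compound 4 (0.12 log units; within the scatter), while 1,2,3,4-tetrahydroquinolin-1-yl in place of 2,3-dihydro-1H-indol-1-yl on an aromatic carbon gives a 1.6-fold higher number from compound 1 to compound 4 (0.22 log units; within the scatter). All three single changes stay within the scatter, so none of these three places is shown to move the number in this small set.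

Nothing available here explains why the numbers lie where they do. Still open, as far as these compounds go, is whether another amine on the same chain carbon, such as morpholin-4-yl or 4-methylpiperazin-1-yl, or a chain without an amine, would move the number beyond the scatter in this assay.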